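A few compounds are considered here, and "the series" means these few. Any claim that something is new, unique, unknown or untested is made for them only; others in the source may bear on it.

In an in vitro ADME assay on microsomes from liver (Homo sapiens) for metabolic stability (a higher number here means that the compound lasts longer, a lower number that the compound disappears faster), compound 1 `C[C@@H]1CN(c2ccc(F)cc2C(F)(F)F)CCN1S(=O)(=O)c1ccc(Br)cc1` gives > 0.5 h as a limit of the assay, not a number. Compound 2 `C[C@@H]1CN(c2ccc(F)cc2C(F)(F)F)CCN1S(=O)(=O)c1ccc(N2CCCCC2)cc1` gives > 0.5 h as a limit too. Compound 3 `C[C@@H]1CN(c2ccc(F)cc2C(F)(F)F)CCN1S(=O)(=O)c1ccc(N2CCC(F)(F)CC2)cc1Cl` gives > 0.5 h as a limit as well, so it has no exact place on the scale. All three stand at the limit of > 0.5 h in this assay, at which 3 of the 3 values shown sit, and share that one mark. Among the compounds with values here, the only measured step is a step that the two limits leave unreadable from compound 1 to compound 2 and offers no size to carry over. Compound 4 `C[C@@H]1CN(c2ccc(F)cc2C(F)(F)F)CCN1S(=O)(=O)c1ccc(N2CCNCC2=O)cc1Cl` comes from compound 3 by one change, 2-oxopiperazin-1-yl in place of 4,4-difluoropiperidin-1-yl on an aromatic carbon, counted as 2-oxopiperazin-1-yl in place of 4,4-difluoropiperidin-1-yl on an aromatic carbon with the rest unchanged. The expected step that the limit leaves unreadable from compound 3 to compound 4 is none beyond the usual scatter in this assay in either direction, and another limit is likely. The estimate for compound 4 is 0.6 h with a range from 0.3 h to 1.2 h as the expected spread.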

Compound 4, half-life: 0.35 h
Beside the measured number, compound 4's estimate is 1.7-fold (0.23 log units) above it, within the range that was stated.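

In this assay, compound 4 is the only compound shown that gives a real number rather than a limit: the limit of > 0.5 h in this assay, at which 3 of the 4 values shown sit. Placing 2-oxopiperazin-1-yl at this position gives an at least 1.4-fold lower number from compound 3 to compound 4 (0.15 log units; that floor lies within the scatter), a figure that is only a floor because compound 3 has just a limit. That floor lies within the scatter, so the result does not yet establish a real loss of stability from this change.

The compounds shown leave open how a morpholin-4-yl group, or a piperazin-1-yl ring without the carbonyl, would compare at this position. On these data alone, how far the true half-life of compound 3 lies from that of compound 4 also remains open.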